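Amide substituent variation on the shared core

This account rests on a few compounds, and the source may have more. Where it says the series, first, only, none or still open, it means among the compounds named here.

Among the measured compounds shown here, compound 1 `COCCNC(=O)c1cc2cccc(OC)c2oc1=N` stands highest of the two compounds measured so far in an assay on HeLa cells for displacement of a labelled ligand from adenosine receptor A3 (Homo sapiens), read by scintillation counting, with a stated time of 180 min, tested at 10 uM; a lower number here means less inhibition, a higher number more inhibition at the concentration tested (going by the name of the read-out): compound 1 gives 15%. Compound 2 `COCCNC(=O)c1cc2cccc(OC)c2oc1=O` gives 0% in this assay, a gap from compound 1 that lies beyond the scatter. For the measured compounds named here, no pair of measured compounds differs in a single place, so nothing is yet known from the data about varying the group on the amide-type nitrogen.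

Compound 3 `CCC(CO)NC(=O)c1cc2cccc(OC)c2oc1=N` differs from compound 1 in exactly that position: 1-(hydroxymethyl)propyl in place of 2-methoxyethyl on an amide-type nitrogen. The entering group carries one hydrogen-bond donor where the leaving group had none, and one heavy atom more.

Going by the values given here, with no measured step bearing on this position, the expected step from compound 1 to compound 3 is a number 1 percentage points lower from compound 1 to compound 3 (within the scatter), not beyond the scatter in either direction. Compound 3 is therefore estimated to give 14% in this assay, within a range of 0% to 32%.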

Compound 3, a percentage reported as inhibition, at one concentration (the size of the read-out at that concentration, not a potency): 6%
Compound 3: the middle estimate sits 8 percentage points above what was measured, and the stated range covers the measured number.
By their numbers in this assay, from the lowest: compounds 2, 3 and 1 (each within the scatter of the next, the first and the last beyond it).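

In this assay, among the compounds shown here, the exchange of 2-methoxyethyl for 1-(hydroxymethyl)propyl on the amide-type nitrogen gives the first measured step at this position: a number 9 percentage points lower from compound 1 to compound 3 (within the scatter). On the core of compound 1, then, these two groups cannot be told apart in this read-out, even though 1-(hydroxymethyl)propyl carries a hydrogen-bond donor and 2-methoxyethyl carries none. No measurement is at hand that bears on the reason for this result.

For the compounds shown here, this single step covers only two closely sized open-chain groups, so it remains open whether a benzyl group, a longer alkyl chain, an amine or a carboxylic acid on this nitrogen would move the number beyond the scatter. A read-out at one concentration also leaves the potency of these compounds open.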